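A few compounds are considered here, and "the series" means these few. Any claim that something is new, unique, unknown or untested is made for them only; others in the source may bear on it.

Compound 1, `Cn1c(-c2ccc(NC(=O)CSc3nc4ccccc4o3)cc2)nc(-c2ccccc2)c1-c1ccccc1`: 18.7%
Compound 2, `Cn1cnnc1SCC(=O)Nc1ccc(-c2nc(-c3ccccc3)c(-c3ccccc3)n2C)cc1`: 33.1%
Compound 3, `Cn1nnnc1SCC(=O)Nc1ccc(-c2nc(-c3ccccc3)c(-c3ccccc3)n2C)cc1`: 21.9%

These three compounds were tested in a functional assay on MCF7 cells (Homo sapiens) for cytotoxicity, read by MTT assay, with a stated time of 24 h, tested at 0.64 ug/mL; on this read-out lower numbers stand for a weaker effect and higher numbers for a stronger effect at the one concentration tested. Compound 3 holds the second highest of the three numbers: it lies within the scatter of compound 1, while compound 2 stands beyond the scatter above it. All three share one core and differ only in the group attached to the sulfur.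

Compound 4, `Cn1ccnc1SCC(=O)Nc1ccc(-c2nc(-c3ccccc3)c(-c3ccccc3)n2C)cc1`, has not yet been measured. 1-methyl-1H-imidazol-2-yl in place of 1-methyl-1H-tetrazol-5-yl on a sulfur

The measured steps that bear on this are the other swaps of the group on the sulfur: a number 14.4 percentage points higher from compound 1 to compound 2 (beyond the scatter), a number 3.2 percentage points higher from compound 1 to compound 3 (within the scatter) and a number 11.2 percentage points lower from compound 2 to compound 3 (beyond the scatter). Such swaps have moved the read-out by modest amounts at most, in either direction, with no group matching the one that enters here. A step of at most modest size is therefore expected, its direction uncertain, and the estimate is placed near the middle of the measured range: compound 4 is expected to give 27%, between 14% and 40%, which means an expected a number 5.1 percentage points higher from compound 3 to compound 4 (within the scatter).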

Compound 4, a percentage reported as activity, at one concentration (the size of the read-out at that concentration, not a potency): 10.3%
The estimate for compound 4 lay 16.7 percentage points above the measured number; measured number below the stated range.
By their numbers in this assay, from the lowest: compounds 4, 1 and 3 (each within the scatter of the next, the first and the last beyond it); then compound 2.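

In this assay the group on the sulfur can pull the number down as well as push it up: 1-methyl-1H-imidazol-2-yl gives a number 11.6 percentage points lower from compound 3 to compound 4 (beyond the scatter) and also a number 22.8 percentage points lower from compound 2 to compound 4 (beyond the scatter) as the largest step yet at this position. The 1-methyl-1H-tetrazol-5-yl and 1-methyl-1H-imidazol-2-yl groups both count 6 heavy atoms in one five-membered aromatic ring, so a step of this size can arise from exchanging ring nitrogen for ring carbon, with that count unchanged. The swap from 1,3-benzoxazol-2-yl gives a number 8.4 percentage points lower from compound 1 to compound 4 (within the scatter) and so does not separate those two groups.

Nothing available explains why these ring swaps move the number. Also open, on these data alone, is how a pyridin-2-yl ring, a plain methyl group or a carboxylic acid on a short chain would behave on the sulfur.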